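Removing tert-butyl from compound 3

The source may hold more compounds than are shown below. What is called first, only, known or untested is meant among the compounds shown, and "the series" means these compounds.

Measured in a functional assay on CWR22R cells (Homo sapiens) for antiproliferative activity, with a stated time of 96 h; a higher number here means a weaker inhibitor, a lower number a stronger inhibitor:
- compound 1 `Cc1cc(=O)oc2cc(OCC(=O)c3ccc(C(C)(C)C)cc3)ccc12`: 22300 nM
- compound 2 `Cc1cc(=O)oc2cc(OCC(=O)c3ccc(C#N)cc3)ccc12`: > 100000 nM, a limit of the assay
- compound 3 `CC(C)(C)c1ccc(C(=O)COc2ccc3c(C(F)(F)F)cc(=O)oc3c2)cc1`: "not active" (no number reported)

Compound 3 has no number in this assay, and compound 3 stands only as "not active" (no number reported). Compound 4 `O=C(COc1ccc2c(C(F)(F)F)cc(=O)oc2c1)c1ccccc1` differs from compound 3 by hydrogen in place of tert-butyl on an aromatic carbon. Among the compounds with values here, the only measured step that also removes tert-butyl, with cyano in its place, is an at least 4.4-fold higher number from compound 1 to compound 2 (0.65 log units; beyond the scatter), beyond the scatter. Compound 4 is therefore expected to gain no strength over compound 3, though the size of the step cannot be given without a number for compound 3. The expected value for compound 4 is 70000 nM, with an estimated range from 25000 nM to 100000 nM.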

Compound 4, half-maximal inhibitory concentration: "not active" (no number reported)
Nothing numeric was reported for compound 4, and the estimate cannot be compared.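

Compound 3 and compound 4 are both reported as "not active" in this assay, without a number, so no step can be read between them. The compounds shown leave open whether removing tert-butyl changes strength in the trifluoromethyl pair. Nothing shown bears on this result.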